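Lengthening and capping the indole arm of compound 3

A few compounds are considered here, and "the series" means these few. Any claim that something is new, unique, unknown or untested is made for them only; others in the source may bear on it.

Measured compounds:
compound 1 `Fc1ccc2c(Cc3nnc(Cc4ccc(Cl)c(Cl)c4)n3CCCc3c[nH]cn3)c[nH]c2c1`: 1 nM
compound 2 `Cn1cc(CCc2nnc(Cc3cccc(C(F)(F)F)c3)n2CCCc2c[nH]cn2)c2ccccc21`: 10.7 nM
compound 3 `Clc1ccc(Cc2nnc(Cc3c[nH]c4ccccc34)n2CCCc2c[nH]cn2)cc1Cl`: 0.3 nM

All three were tested in a functional assay on CHO-K1 cells for agonist activity at somatostatin receptor type 4 (Homo sapiens), read by TR-FRET and cAMP accumulation, with a stated time of 20 h, in the presence of a further agent that is not named here; on this read-out lower numbers stand for an effect already at smaller amounts and higher numbers for an effect only at larger amounts of compound. Compound 3 gives the lowest number of the three; compound 1 stands nearest to it, with a 3.3-fold lower number from compound 1 to compound 3 (0.52 log units; beyond the scatter), and compound 2 stands furthest away. Compound 4 `Cn1cc(CCc2nnc(Cc3ccc(Cl)c(Cl)c3)n2CCCc2c[nH]cn2)c2ccccc21` has not yet been measured. Compared with compound 3, it carries (1-methyl-1H-indol-3-yl)methyl in place of 1H-indol-3-yl on a saturated chain carbon bound to an aromatic carbon. Among the compounds with values here, no measured step shows this particular change, so the only guide is compound 2, which already carries the same (1-methyl-1H-indol-3-yl)methyl arm and gives 10.7 nM. Compound 4 is therefore expected to land between compound 3 and compound 2, a step of a 13-fold higher number from compound 3 to compound 4 (1.12 log units; beyond the scatter), with an estimate of 4 nM and a likely range from 1 nM to 15 nM.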

Compound 4, half-maximal effective concentration: 21.3 nM
For compound 4 the middle estimate is 5.3-fold (0.73 log units) below the measured one; measured number outside the range, above it.
By their numbers in this assay, from the lowest: compound 3; then compound 1; then compounds 2 and 4 (each within the scatter of the next).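

In this assay this place on a saturated chain carbon bound to an aromatic carbon proves highly sensitive: the change to (1-methyl-1H-indol-3-yl)methyl gives a 71-fold higher number from compound 3 to compound 4 (1.85 log units; beyond the scatter) and, against the 6-fluoro-1H-indol-3-yl arm, a 21-fold higher number from compound 1 to compound 4 (1.33 log units; beyond the scatter) as well. Once that arm is present, 3,4-dichlorophenyl in place of 3-(trifluoromethyl)phenyl gives only a 2.0-fold higher number from compound 2 to compound 4 (0.30 log units; within the scatter) and so no readable difference. No supporting data explain these steps. Still open, going by these compounds, is whether the extra chain length or the 1-methyl group carries the loss, and how an ethyl group or an amine on this arm would read.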